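The compounds below may be only part of what the source reports. "The series", "measured", "known", "first", "only" and "open" are said of these compounds alone.

Compound 1 `CN1CCN(c2nc(-c3ccc(Cl)c(Cl)c3)nc3[nH]cnc23)CC1` was tested in an assay on cells for displacement of a labelled ligand from adenosine receptor A2b (Homo sapiens), read by scintillation counting and radioligand binding, with a stated time of 30 min, tested at 10 uM (a higher number here means more inhibition at the concentration tested (going by the name of the read-out), a lower number less inhibition), where compound 1 gives 24.1%. Going by the values given here, only one other compound has a number here: compound 2 `CN1CCN(c2nc(-c3ccc(Cl)c(Cl)c3)nc3c2ncn3C)CC1`, which carries a methyl group on an aromatic nitrogen of the shared core, and in this assay compound 2 gives 28.3%. The step of a number 4.2 percentage points higher from compound 1 to compound 2 (within the scatter) lies within the scatter, so these two numbers cannot be told apart, and compound 1 is not set apart from compound 2 in either direction.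

Compound 3 `CN1CCN(c2nc(-c3ccc(Cl)cc3)nc3[nH]cnc23)CC1` is not yet measured. Compound 3 differs from compound 1 in one place: hydrogen in place of chloro on an aromatic carbon. Among the compounds with values here, the measured step between compound 1 and compound 2 touches a different part of the molecule, the aromatic nitrogen rather than the six-membered aromatic ring of carbon only, so no measured step bears on this change. Without such a step, no shift beyond the scatter is expected for compound 3, whose estimated step is a number 4.1 percentage points lower from compound 1 to compound 3 (within the scatter). For compound 3 the value in this assay is therefore estimated at 20%, with a range from 5% to 40%.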

Compound 3, a percentage reported as inhibition, at one concentration (the size of the read-out at that concentration, not a potency): 6.2%
For compound 3 the middle estimate is 13.8 percentage points above the measured one; measured number inside the range.
By their numbers in this assay, from the lowest: compound 3; then compounds 1 and 2 (each within the scatter of the next).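

In this assay, the chloro group on this aromatic carbon proves to make a difference: replacing it with hydrogen, which turns 3,4-dichlorophenyl into 4-chlorophenyl, gives a number 17.9 percentage points lower from compound 1 to compound 3 (beyond the scatter) in this pair. This is the first step among these compounds to lie beyond the scatter, so a change at this place on the six-membered aromatic ring can shift the read-out in a way that methyl in place of hydrogen on the aromatic nitrogen did not, although the shift is modest and rests on a single pair at one concentration. Nothing available here explains the drop.

From the compounds shown here alone, it remains open whether a group other than chloro or hydrogen at this place, such as methyl, methoxy or an amine, would give a higher or lower number than compound 1. Also open, going by these compounds, is whether removing this chloro group from compound 2, which carries the methyl group on the aromatic nitrogen, would produce a step of similar size.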